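A Larger Aryl Group Replaces a Methyl on the Core

The compounds below may be only part of what the source reports. "The series", "measured", "known", "first", "only" and "open" are said of these compounds alone.

Three compounds share a core and were followed in the same test. Compound 1, `C[C@H](Nc1nc(N)nc(N)c1C#N)c1cc(=O)n2cc(F)ccc2c1-c1ccccc1`, has no number in an ADME assay on microsomes from liver (Rattus norvegicus), read by LC-MS, using NADPH, with a stated time of 30 min, tested at 1 uM; a higher number here means that more of the compound is left, a lower number that less of the compound is left; for compound 1 the entry reads "not determined" (no result reported). Compound 2, `C[C@H](Nc1nc(N)nc(N)c1C#N)c1cc(=O)n2cc(F)ccc2c1-c1cc(F)cc(F)c1`, gives in this assay 87%. Compound 3, `Cc1c([C@H](C)Nc2nc(N)nc(N)c2C#N)c(-c2ccccc2)c(=O)n2cc(F)ccc12`, gives in this assay 85%. Of the two numbers that exist, compound 3 stands alongside compound 2, the gap between them being within the scatter of the measurement, so the two cannot be told apart on this evidence.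

Compound 4, `C[C@H](Nc1nc(N)nc(N)c1C#N)c1c(-c2ccccc2)c(=O)n2cc(F)ccc2c1-c1ccc(C(N)=O)cc1`, differs from compound 3 in one place: 4-carbamoylphenyl in place of methyl on an aromatic carbon. Among the compounds with values here, no pair of measured compounds traces a step of this kind, so the size of the effect in this assay rests on no comparison within the set. The step of a number 7 percentage points lower from compound 3 to compound 4 (within the scatter) is expected to be modest, most likely within the scatter or only a little downward, since both measured compounds sit high and leave limited room upward. For compound 4 the estimated value is 78%, with a range from 55% to 95%.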

Compound 4, percent of the compound remaining: 100%
Compound 4: middle estimate off by 22 percentage points, on the low side, and the stated range ends below it.
By their numbers in this assay, from the lowest: compounds 3 and 2 (each within the scatter of the next); then compound 4.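

In this assay the exchange of methyl for 4-carbamoylphenyl on an aromatic carbon of the shared core gives a number 15 percentage points higher from compound 3 to compound 4 (beyond the scatter), with compound 4 at 100%. The earlier compounds shown here offered no step at this position, and this first one shows that the carbon, ortho to a fused ring and ortho to a large group, can carry a far larger group, one with a six-membered aromatic ring of carbon only, with no loss in the percent of the compound remaining. Within the data shown here, nothing measured here bears on what lies behind this rise, and the single step gives no cause for it.

What the compounds shown leave open is which part of the new group goes with the higher number, the aromatic ring itself or the carbamoyl group at its 4-position, a question that a plain phenyl, a 4-carboxyphenyl or a 4-aminophenyl group at the same carbon would help to settle. They also leave open whether the same exchange would give a similar step on the other compounds of the set, such as the one with the 3,5-difluorophenyl group, compound 2.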